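The source may report more compounds than this note shows. Statements on the series, on what has been measured and on what is new or still open speak of the compounds shown alone.

Compound 1 `O=C(CN1CCC(c2cccc[n+]2[O-])CC1)Nc1cccc(Cl)c1` and compound 2 `Cc1cccc(NC(=O)CN2CCC(c3ccccc3C#N)CC2)c1` are built on a shared core. In a functional assay on HEK293 cells for agonist activity at D(4) dopamine receptor (Homo sapiens), read by FLIPR (on this read-out lower numbers stand for smaller maximal responses and higher numbers for larger maximal responses), compound 1 gives 76%, and compound 2 gives 71%; these two numbers lie within the usual scatter of each other, so neither stands apart from the other. Compound 3 `O=C(CN1CCC(c2cccc[n+]2[O-])CC1)Nc1ccc(F)cc1F` has not yet been measured in this assay. It differs from compound 1 in one place: 2,4-difluorophenyl in place of 3-chlorophenyl on an amide-type nitrogen. Among the compounds with values here, no measured pair shows a change of this kind, so only a small step is expected, a number 4 percentage points lower from compound 1 to compound 3 (within the scatter), with no direction beyond the scatter. Compound 3 is estimated to reach 72%, likely between 52% and 90%.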

Compound 3, largest response reached (reported as efficacy), in percent of the reference or control that the assay uses: 74%
The estimate for compound 3 lay 2 percentage points below the measured number; the range from low to high includes it.
By their numbers in this assay, from the lowest: compounds 2, 3 and 1 (each within the scatter of the next).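

Placing 2,4-difluorophenyl in place of 3-chlorophenyl on the amide-type nitrogen gives a number 2 percentage points lower from compound 1 to compound 3 (within the scatter) in this assay. Within the data shown here, this is the first measured pair that differs at this place, and on this read-out its two compounds cannot be told apart. No available measurement bears on what lies behind this result.

Going by these compounds, what a plain phenyl or a cyclohexyl on that nitrogen would give remains open. So does whether any group at this place would shift the maximal response beyond the scatter.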